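The source may hold more compounds than are shown below. What is called first, only, known or untested is meant among the compounds shown, and "the series" means these compounds.

The measured compounds in an assay on cells for inhibition of S-adenosylmethionine decarboxylase proenzyme (Homo sapiens), read by mass spectrometry, at pH 7.2; on this read-out higher numbers stand for weaker inhibition and lower numbers for stronger inhibition:

Compound 1 `Nc1nccc(Nc2cc(Cl)cc(Cl)c2)n1` gives > 180000 nM, which is a limit of the assay.
Compound 2 `CCCCOc1cc(Br)cc(Nc2cc(C)nc(N)n2)c1` gives > 180000 nM, likewise a limit.
Compound 3 `Cc1cc(Nc2cc(Cl)c(Oc3ccccc3)c(Cl)c2)nc(N)n1` gives > 180000 nM, again a limit.

On the numbers shown, compound 3 therefore stands nowhere in particular: it sits at the limit of > 180000 nM in this assay, at which 3 of the 3 values shown sit, and the other two compounds sit there as well, so no ranking among the three is possible in this assay.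

Compound 4 `Cc1cc(Nc2cc(Cl)c(N(C)C)c(Cl)c2)nc(N)n1` has not yet been measured. It differs from compound 3 in one place: dimethylamino in place of phenoxy on an aromatic carbon. Going by the values given here, no step between measured compounds is available to give a size or a direction for this change, and the three values known are all limits, so they carry no slope at all. The expectation for compound 4 is that it too remains weak in this assay, with the step that the limit leaves unreadable from compound 3 to compound 4 expected to be none beyond the scatter. Compound 4 is estimated at 200000 nM, with a range from 50000 nM to 1000000 nM.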

Compound 4, half-maximal inhibitory concentration: > 180000 nM
Compound 4 was reported as a limit; the forecaster's own chance of this, stated with the estimate: 75%; the middle value lies beyond the limit too.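

In this assay compound 3 and compound 4 are both reported only as limits, so no step can be read between them: the limit of > 180000 nM in this assay, at which 4 of the 4 values shown sit.

In this assay the compounds shown leave open which change to the shared core, if any, would give a readable value.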